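Chloro in place of hydroxymethyl on the pendant phenyl

The source may hold more compounds than are shown below. What is called first, only, known or untested is meant among the compounds shown, and "the series" means these compounds.

Compound 1 `COCc1cccc(-c2ccc3ccc(C)nc3c2)c1` gives 5800 nM in a functional assay on CHO cells for inhibition of metabotropic glutamate receptor 5 (Rattus norvegicus), read by FLIPR and calcium flux; a lower number here means a stronger inhibitor, a higher number a weaker inhibitor. Compound 2 `Cc1ccc2ccc(-c3cccc(CO)c3)cc2n1` gives 8700 nM; the step of a 1.5-fold higher number from compound 1 to compound 2 (0.18 log units; within the scatter) changes nothing that stands beyond the scatter. Among the measured compounds shown here, compound 2 thus carries the higher of the two numbers so far, though its gap to compound 1 is within the scatter, so no order between them is claimed.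

Compound 3 `Cc1ccc2ccc(-c3cccc(Cl)c3)cc2n1` differs from compound 2 by chloro in place of hydroxymethyl on an aromatic carbon. The only measured step, from compound 1 to compound 2, touched the same aromatic carbon but kept the oxygen; none of the shown steps removes an oxygen-bearing substituent or introduces a halogen, so the data give no direct guide. The step from compound 2 to compound 3 is therefore expected to be modest, with a slight lean toward a lower number, a 2.9-fold lower number from compound 2 to compound 3 (0.46 log units; beyond the scatter). Compound 3 is expected at 3000 nM, within 700 nM to 13000 nM.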

Compound 3, half-maximal inhibitory concentration: 14000 nM
Compound 3: middle estimate off by 4.7-fold (0.67 log units), on the low side, outside the stated range (above it).
By their numbers in this assay, from the lowest: compounds 1, 2 and 3 (each within the scatter of the next, the first and the last beyond it).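

Replacing hydroxymethyl with chloro on this aromatic carbon gives a 1.6-fold higher number from compound 2 to compound 3 (0.21 log units; within the scatter) in this assay, so these two groups are not separated here, even though chloro has no hydrogen-bond donor or acceptor and hydroxymethyl has one of each. Set against methoxymethyl, the same chloro gives a 2.4-fold higher number from compound 1 to compound 3 (0.38 log units; beyond the scatter) as the first step in the series to pass the scatter, though it is modest and separates only the two ends of a narrow set of numbers. No measurement shown here explains either step.

From the compounds shown here alone, whether an amine, a carboxylic acid or a longer ether chain on this aromatic carbon would give a number clearly lower than that of compound 1 remains open. Also open, going by these compounds, is whether chloro would read the same on another carbon of this ring.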